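Fluoro to hydrogen: cytotoxicity expected for compound 4

The compounds below may be only part of what the source reports. "The series", "measured", "known", "first", "only" and "open" are said of these compounds alone.

In an ADME assay on HeLa cells (Homo sapiens) for cytotoxicity, read by ATP content, with a stated time of 3 days (on this read-out higher numbers stand for lower toxicity in this test and lower numbers for higher toxicity in this test), compound 1 `N#CCCCn1c(Cn2c(=O)n(-c3ncccn3)c3ccncc32)cc2cc(Cl)ccc21` gives > 50000 nM, a limit of the assay.
In this assay compound 2 `COc1ccc(-n2c(=O)n(Cc3cc4cc(Cl)ccc4n3CCCC#N)c3cnccc32)c(C)c1` gives > 50000 nM, also a limit.
In this assay compound 3 `COc1ccc(-n2c(=O)n(Cc3cc4cc(Cl)ccc4n3CCCC#N)c3cnccc32)c(F)c1` gives > 50000 nM, again a limit.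

Compound 3 therefore stands where the other two measured compounds stand: at the limit of > 50000 nM in this assay, at which 3 of the 3 values shown sit, and no number separates it from compound 1 or compound 2. The step that the two limits leave unreadable from compound 1 to compound 3 and the step that the two limits leave unreadable from compound 1 to compound 2 are both unreadable for this reason, and so is the step that the two limits leave unreadable from compound 2 to compound 3, which exchanges one small group on the aromatic carbon for another.

Compound 4 `COc1ccc(-n2c(=O)n(Cc3cc4cc(Cl)ccc4n3CCCC#N)c3cnccc32)cc1` differs from compound 3 by hydrogen in place of fluoro on an aromatic carbon. Of the measured steps, the step that the two limits leave unreadable from compound 2 to compound 3 is the nearest in kind, since it also alters a single small substituent at that aromatic carbon, and it left the read-out at the limit. Within the data shown here, none of the measured steps gives a readable size, so no direction can be derived from them; the expectation is that compound 4 will again sit at the limit, with a step that the limit leaves unreadable from compound 3 to compound 4 estimated to be nothing beyond the scatter. The estimate for compound 4 in this assay is 60000 nM, with a range from 30000 nM to 120000 nM.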

Compound 4, half-maximal cytotoxic concentration: > 50000 nM
Compound 4 gave a limit, no number; the forecaster's own chance of this, stated with the estimate: 85%; the middle value is on the limit's open side.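

In this assay compound 4 gives > 50000 nM, a limit and not a number. Among these compounds, no step among compound 1, compound 2, compound 3 and compound 4 can be read, and all four stand together: the limit of > 50000 nM in this assay, at which 4 of the 4 values shown sit. The compounds shown leave open how far any of them lies beyond the limit, and whether the exchanged groups alter the read-out at all.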